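This account rests on a few compounds, and the source may have more. Where it says the series, first, only, none or still open, it means among the compounds named here.

Compound 1, `COc1cc2oc(-c3cccc(NC(=O)c4ccc(C)cc4)c3)cc(=O)c2c(OC)c1OC`, carries a methyl on the outer aromatic ring of the amide, and in a functional assay on UACC-62 cells (Homo sapiens) for inhibition, read by sulforhodamine B assay, tested at 10 uM (on this read-out lower numbers stand for less inhibition and higher numbers for more inhibition at the one concentration tested (going by the name of the read-out)), compound 1 gives 50.8%. Compound 2, `COc1cc2oc(-c3cccc(NC(=O)c4ccc(Br)cc4)c3)cc(=O)c2c(OC)c1OC`, has bromo at that place, and in this assay compound 2 gives 39.1%. Within the data shown here, the one measured step, a number 11.7 percentage points lower from compound 1 to compound 2 (beyond the scatter), shows that exchanging the group on that ring moves the number by a modest but real amount. Among the measured compounds shown here, compound 2 thus holds the lower of the two numbers recorded so far, with compound 1 as its only neighbour.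

Compound 3 is `COc1cc2oc(-c3cccc(NC(=O)c4ccc([N+](=O)[O-])cc4)c3)cc(=O)c2c(OC)c1OC`. It differs from compound 2 as follows: nitro in place of bromo on an aromatic carbon. For the measured compounds named here, the only step that bears on this change is the methyl-to-bromo step, which gives the scale of what one exchange at this place can do, but its direction cannot be carried over, since no compound with nitro has been measured. Compound 3 is therefore expected to lie near compound 2, with a change of a number 0.9 percentage points higher from compound 2 to compound 3 (within the scatter) and an estimated value of 40%, in the range 22% to 58%.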

Compound 3, a percentage reported as inhibition, at one concentration (the size of the read-out at that concentration, not a potency): 52.1%
Estimate against measurement, compound 3: 12.1 percentage points below; measured number inside the range.
By their numbers in this assay, from the lowest: compound 2; then compounds 1 and 3 (each within the scatter of the next).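

In this assay, nitro in place of bromo gives a number 13 percentage points higher from compound 2 to compound 3 (beyond the scatter), so the drop seen on going from methyl to bromo does not mean that every replacement of methyl at this place lowers the number. Nitro in place of methyl gives a number 1.3 percentage points higher from compound 1 to compound 3 (within the scatter), so these two groups cannot be told apart in this read-out, while compound 2, with its bromo, lies beyond the scatter from both. Nothing available explains why bromo stands apart from methyl and nitro here.

Going by these compounds, whether an amine, a methoxy group or a carboxylic acid at this place would sit with compound 1 and compound 3 or with compound 2 remains open, as does whether chloro or fluoro would track bromo. Also open, on these data alone, is whether the same three groups would keep this order on another carbon of that ring, and whether these numbers at a single concentration would carry over to full measures of potency.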